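The source may hold more compounds than are shown below. What is called first, only, known or untested is meant among the compounds shown, and "the series" means these compounds.

Compound 1 `CCOC(=O)Nc1sc(-c2ccc(Cl)cc2)c(-c2ccc(Cl)cc2)c1C(=O)NC1CC1` and compound 2 `CN1CCN(C(=O)c2c(N)sc(-c3ccc(Cl)cc3)c2-c2ccc(Cl)cc2)CC1` share a common core and have both been tested in a functional assay on PC-3 cells (Homo sapiens) for inhibition, read by sulforhodamine B assay, with a stated time of 72 h; on this read-out lower numbers stand for stronger inhibition and higher numbers for weaker inhibition. In that assay compound 1 gives 27600 nM, while compound 2 gives 13100 nM, the lower of the two numbers; the gap between them lies beyond the usual scatter, so compound 2 is the stronger inhibitor of the pair. Compound 3 `CC1CCN(C(=O)c2c(N)sc(-c3ccc(Cl)cc3)c2-c2ccc(Cl)cc2)CC1` has not yet been measured in this assay. It differs from compound 2 in one place: 4-methylpiperidin-1-yl in place of 4-methylpiperazin-1-yl on a carbonyl carbon. The change puts 4-methylpiperidin-1-yl in place of 4-methylpiperazin-1-yl on the carbonyl carbon, and the rest of the structure stays untouched. Within the data shown here, no measured pair shows how this change acts in this assay, so the expected step, a 1.0-fold lower number from compound 2 to compound 3 (0.00 log units; within the scatter), is taken to stay within the usual scatter, with no clear direction. On that basis compound 3 is estimated at 13000 nM, within a range from 4000 nM to 40000 nM.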

Compound 3, half-maximal inhibitory concentration: 5750 nM
For compound 3 the middle estimate is 2.3-fold (0.35 log units) above the measured one, within the range that was stated.
By their numbers in this assay, from the lowest: compound 3; then compound 2; then compound 1.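

In this assay putting 4-methylpiperidin-1-yl in place of 4-methylpiperazin-1-yl on the carbonyl carbon gives a 2.3-fold lower number from compound 2 to compound 3 (0.36 log units; beyond the scatter) and thus shows that the group held at this position can shift the read-out, if only modestly. Both groups are six-membered non-aromatic rings of equal heavy-atom size, so this modest step accompanies a carbon standing in place of a ring nitrogen, with one hydrogen-bond acceptor fewer in the entering group. No measured information on hand accounts for the step.

As far as these compounds go, whether the ring methyl group contributes remains open, as would be tested by an unsubstituted piperidin-1-yl, and a morpholin-4-yl or an open-chain diethylamino group would show how far other groups on the carbonyl carbon follow this step. From the compounds shown here alone, it also remains open whether the same change would act alike with the ethyl carbamate and cyclopropyl amide of compound 1 in place.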